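Sulfone series: lipophilicity notes on compounds 2 and 3

A few compounds are considered here, and "the series" means these few. Any claim that something is new, unique, unknown or untested is made for them only; others in the source may bear on it.

Measured so far:
- compound 1 `C[n+]1ccn(COCCCCS(C)(=O)=O)c1/C=N/O`: -3.11
- compound 2 `C[n+]1ccn(COCCS(=O)(=O)c2ccccc2)c1/C=N/O`: -2.39

In a physicochemical assay for lipophilicity (on this read-out lower numbers stand for lower lipophilicity and higher numbers for higher lipophilicity), compound 2 gives -2.39, the higher of the two numbers. Its nearest neighbour is compound 1, which in this assay gives -3.11, a number lower by more than the usual scatter. Compound 1 and compound 2 differ in several places at once, so no single-change step can be read from them; only their two values are known.

Compound 3 `CCS(=O)(=O)CCOCn1cc[n+](C)c1/C=N/O` is not yet measured. Relative to compound 2 the change is ethyl in place of phenyl on a sulfonyl sulfur. Among the compounds with values here, no step between measured compounds isolates this change. Going from a six-membered aromatic ring to a two-carbon chain on the sulfonyl sulfur is expected to lower this assay by a step clearly beyond the scatter, estimated as a number 0.81 log units lower from compound 2 to compound 3 (beyond the scatter). For compound 3 the expected value in this assay is -3.2, with a range from -3.7 to -2.7.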

Compound 3, distribution coefficient: < -2.7
Compound 3: only a limit was reported (the forecaster's own chance of this, stated with the estimate: 5%); the middle value lies beyond the limit too.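

In this assay compound 3 gives < -2.7, which is a limit of the assay and not a number. Ethyl in place of phenyl on a sulfonyl sulfur is the first single change in this series that can be read, and it gives a number at least 0.31 log units lower from compound 2 to compound 3 (beyond the scatter). The group at this place, on a sulfonyl sulfur whose other neighbour is a saturated chain carbon, therefore moves the read-out by more than the scatter, although only the smallest possible size of the step is known.

The step from compound 1 to compound 3 cannot be read, and the full size of the change stays unknown, because of the limit: the limit of < -2.7 in this assay, at which 1 of the 3 values shown sits.
From the compounds shown here alone, whether the aromatic ring or the carbon count drives the step stays open, and a butyl chain or a cyclohexyl ring on this sulfur would separate the two.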